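The source may report more compounds than this note shows. Statements on the series, on what has been measured and on what is new or still open speak of the compounds shown alone.

Measured in a functional assay on Malme-3M cells (Homo sapiens) for cytotoxicity, read by MTT assay, with a stated time of 6 days; a lower number here means that less compound is needed, a higher number that more compound is needed for the effect:

Compound 1 `COC(=O)c1c(-c2ccc(Br)cc2)oc2ccccc2c1=O`: > 25 ug/mL, a limit
Compound 2 `COC(=O)c1c(-c2ccc([N+](=O)[O-])cc2)oc2ccccc2c1=O`: > 25 ug/mL, a limit
Compound 3 `COC(=O)c1c(-c2ccc([N+](=O)[O-])cc2)oc2cc(OC)ccc2c1=O`: 1.12 ug/mL

Compound 2 has no exact number. Its entry of > 25 ug/mL is only a limit of this assay. That entry is the limit of > 25 ug/mL in this assay, at which 2 of the 3 values shown sit.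

Compound 4 `COC(=O)c1c(-c2ccc(OCc3ccccc3)cc2)oc2ccccc2c1=O` is not yet measured. It differs from compound 2 by benzyloxy in place of nitro, on an aromatic carbon of a six-membered aromatic ring of carbon only, para to a large group: benzyloxy in place of nitro on an aromatic carbon.

Two measured steps can be weighed. The first exchanges bromo for nitro and is a step that the two limits leave unreadable from compound 1 to compound 2. It gives no size, but neither compound yields a number. The second adds a methoxy group and is an at least 22-fold lower number from compound 2 to compound 3 (1.34 log units; beyond the scatter). That large step comes from a different change, and compound 4 lacks this methoxy group, so it does not carry over.

Among the measured compounds shown here, no measured step therefore points to a clear shift in either direction, and a step beyond the scatter is not expected. The expected change is a step that the limit leaves unreadable from compound 2 to compound 4. A result reported only as a limit is the likeliest outcome. The estimate for compound 4 is 30 ug/mL, with an expected range of 10 ug/mL to 80 ug/mL.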

Compound 4, concentration for half-maximal effect: > 25 ug/mL
Compound 4: a limit, no number; the forecaster's own chance of this, stated with the estimate: 75%; the middle value lies beyond the limit too.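

Compound 4 gives only a limit, as do compound 1 and compound 2, so no step among these three compounds can be read in this assay: the limit of > 25 ug/mL in this assay, at which 3 of the 4 values shown sit.

As far as these compounds go, it stays open how far bromo, nitro and benzyloxy really differ on the shared core, and whether the methoxy group of compound 3 would bring a similar drop on compound 1 or compound 4.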